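Hydroxy for Methyl on the Aryl Ring of Compound 2

The source may hold more compounds than are shown below. What is called first, only, known or untested is meant among the compounds shown, and "the series" means these compounds.

Measured compounds:
compound 1 `Cc1nn(C)c2c1C(c1cccc(Br)c1)=NCCN2` — 0.63 mg/kg
compound 2 `Cc1cccc(C2=NCCNc3c2c(C)nn3C)c1` — 2.5 mg/kg

In a functional assay on the whole organism for positive allosteric modulation, with Rattus norvegicus as the target (on this read-out lower numbers stand for an effect already at smaller amounts and higher numbers for an effect only at larger amounts of compound), compound 2 gives 2.5 mg/kg, the highest of the two numbers measured; its nearest neighbour is compound 1, which gives 0.63 mg/kg. Within the data shown here, the only step recorded between measured compounds is a 4.0-fold higher number from compound 1 to compound 2 (0.60 log units; beyond the scatter), a methyl in place of bromo on an aromatic carbon.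

Compound 3 `Cc1nn(C)c2c1C(c1cccc(O)c1)=NCCN2` has not yet been measured. It differs from compound 2 by hydroxy in place of methyl on an aromatic carbon.

Among the measured compounds shown here, no measured step bears directly on this change: the bromo-to-methyl step shows that this position tolerates exchange of the substituent with a modest shift in the minimum effective dose, but neither measured compound carries a hydroxy. The expectation therefore rests on a single step and is weak. On balance compound 3 is expected to give a number close to that of compound 2, with a wide range, so the estimated step is a 1.2-fold higher number from compound 2 to compound 3 (0.08 log units; within the scatter). Compound 3 is estimated at 3 mg/kg, within 0.8 mg/kg to 10 mg/kg.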

Compound 3, minimum effective dose: 2.5 mg/kg
Compound 3: the middle estimate sits 1.2-fold (0.08 log units) above what was measured; the range from low to high includes it.
By their numbers in this assay, from the lowest: compound 1; then compounds 2 and 3 (each within the scatter of the next).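

In this assay, hydroxy in place of methyl on this aromatic carbon gives no change at the digits printed from compound 2 to compound 3 (within the scatter), so at this position a group carrying a hydrogen-bond donor and a hydrogen-bond acceptor cannot be told apart from methyl, which carries neither. Hydroxy in place of bromo gives a 4.0-fold higher number from compound 1 to compound 3 (0.60 log units; beyond the scatter), matching in size the step already seen with methyl, a 4.0-fold higher number from compound 1 to compound 2 (0.60 log units; beyond the scatter), and so bromo alone stands apart among the three groups, with compounds 2 and 3 both at the higher number. Nothing available explains why bromo differs from methyl and hydroxy, or why those two match in this read-out.

The compounds shown leave open whether an amine, a carboxylic acid or a methoxy group on the same aromatic carbon would stay with methyl and hydroxy or come closer to bromo, and whether chloro or iodo would share the number of compound 1. With a whole-organism dose as the only read-out, they also leave open whether the matching numbers of compounds 2 and 3 reflect matching action at the target itself.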